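The source may hold more compounds than are shown below. What is called first, only, known or untested is meant among the compounds shown, and "the series" means these compounds.

Notes on the series. The three measured compounds share one core and differ only in the group on the carbon with a double bond to nitrogen. Compound 1 `CN(C)CCn1cnnc1-c1cc(Oc2ccc(NC(=O)N/N=C/c3c(Cl)cccc3Cl)cc2F)ccn1` gives 3320 nM in an ADME assay on WI-38 cells (Homo sapiens) for cytotoxicity, read by MTT assay, with a stated time of 72 h; on this read-out higher numbers stand for weaker inhibition and lower numbers for stronger inhibition. Compound 2 `CN(C)CCn1cnnc1-c1cc(Oc2ccc(NC(=O)N/N=C/c3c[nH]c4ccccc34)cc2F)ccn1` gives 3620 nM in this assay, and compound 3 `CN(C)CCn1cnnc1-c1cc(Oc2ccc(NC(=O)N/N=C/c3ccc(Cl)cc3)cc2F)ccn1` gives 1870 nM in this assay. Among these three numbers compound 3 holds the lowest, though the distances are small: a 1.8-fold lower number from compound 1 to compound 3 (0.25 log units; within the scatter), and a 1.9-fold lower number from compound 2 to compound 3 (0.29 log units; within the scatter). The remaining step, a 1.1-fold higher number from compound 1 to compound 2 (0.04 log units; within the scatter), is also within the scatter, so on the numbers shown the group on this carbon has not moved the read-out beyond the usual repeat-to-repeat variation.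

Compound 4 `CN(C)CCn1cnnc1-c1cc(Oc2ccc(NC(=O)N/N=C/c3ccc(F)cc3Cl)cc2F)ccn1` is not yet measured. Its change from compound 3 is 2-chloro-4-fluorophenyl in place of 4-chlorophenyl on a carbon with a double bond to nitrogen. Among the compounds with values here, the step that bears most closely on it is the one between the two compounds carrying chlorine-bearing phenyl groups, a 1.8-fold lower number from compound 1 to compound 3 (0.25 log units; within the scatter), which stayed within the scatter; the change to the indolyl group of compound 2 gave no larger effect. No step beyond the scatter is therefore expected in this assay for compound 4 a 1.2-fold higher number from compound 3 to compound 4 (0.09 log units; within the scatter). The estimate for compound 4 is 2300 nM, with a range from 1100 nM to 4800 nM.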

Compound 4, half-maximal inhibitory concentration: 2090 nM
Estimate against measurement, compound 4: 1.1-fold (0.04 log units) above; low and high end bracket the measured number.
By their numbers in this assay, from the lowest: compounds 3, 4, 1 and 2 (each within the scatter of the next).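

Notes on compound 4. In this assay, the change to 2-chloro-4-fluorophenyl from 4-chlorophenyl gives a 1.1-fold higher number from compound 3 to compound 4 (0.05 log units; within the scatter), the first step shown between two phenyl groups that both carry chlorine at the same carbon with a double bond to nitrogen, where the entering group adds a fluorine and the ring, donor and acceptor counts and net charge stay as they were. The comparisons with the two other groups, a 1.7-fold lower number from compound 2 to compound 4 (0.24 log units; within the scatter) and a 1.6-fold lower number from compound 1 to compound 4 (0.20 log units; within the scatter), also stay within the scatter, so all four groups shown at this place, three halogen-bearing phenyl groups and 1H-indol-3-yl, now read alike, with no compound going against this, and the addition of fluorine to the ring has not separated compound 4 from the rest. Nothing at hand gives a measured reason for this flat read-out.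

Open, on these data alone, is whether a group of another kind on this carbon, such as an aliphatic amine, a carboxylic acid or a longer alkyl chain, would give a step beyond the scatter. Also open, as far as these compounds go, is whether any change away from this carbon, in the shared core, would move the number in this assay further than these groups have.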